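A few compounds are considered here, and "the series" means these few. Any claim that something is new, unique, unknown or untested is made for them only; others in the source may bear on it.

Of the compounds shown here, two that share a core have been measured in a functional assay on WI-38 VA13 cells (Homo sapiens) for cytotoxicity; on this read-out lower numbers stand for an effect already at smaller amounts and higher numbers for an effect only at larger amounts of compound. Compound 1 `COc1ccc(C(=O)c2sc3nc(-c4cccs4)ccc3c2N)c(OC)c1` carries a ketone bearing a dimethoxyphenyl group, and in this assay compound 1 gives 0.52 ug/mL. Compound 2 `CCOC(=O)c1sc2nc(-c3cccs3)ccc2c1N` carries an ethyl ester on the carbonyl carbon instead. For compound 2 this assay reports only a limit, > 4 ug/mL, the edge of the measured range rather than a number. Within the data shown here, the two compounds differ in more than one spot, so no single step between them can be drawn; what they show is that compound 1 has a number while compound 2 sits at the limit of > 4 ug/mL in this assay, at which 1 of the 2 values shown sits.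

Compound 3 `Nc1c(C(=O)c2cccc(Br)c2)sc2nc(-c3cccs3)ccc12` has not yet been measured. It differs from compound 2 by 3-bromophenyl in place of ethoxy on a carbonyl carbon. With this change compound 3 becomes an aryl ketone again, as compound 1 is. The expected step is an at least 4.0-fold lower number from compound 2 to compound 3 (0.60 log units; beyond the scatter), toward an effect at smaller amounts and larger than the usual scatter. This expectation rests on compound 1, which gives 0.52 ug/mL in this assay. Compound 3 is expected to give about 1 ug/mL, within a range from 0.3 ug/mL to 4 ug/mL.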

Compound 3, half-maximal effective concentration: 0.5 ug/mL
Estimate against measurement, compound 3: 2.0-fold (0.30 log units) above, and the stated range covers the measured number.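

Compound 1 and compound 2 differ in more than one spot, so the earlier data could not tie a shift in this assay to any single change. Compound 3 supplies that link: placing 3-bromophenyl in place of ethoxy on a carbonyl carbon, whose other neighbour is an aromatic carbon, gives an at least 8.0-fold lower number from compound 2 to compound 3 (0.90 log units; beyond the scatter). This shows that the group on this carbonyl carbon matters for the read-out, although the true size of the step stays unknown because compound 2 stands at a limit of the assay rather than at a number: the limit of > 4 ug/mL in this assay, at which 1 of the 3 values shown sits.

The compounds shown do not tell whether the shift depends on the aromatic ring, on the bromine, or on both, and a plain phenyl, a methyl or a dimethylamino group on the same carbonyl carbon would help to separate these possibilities. They also leave open whether the bromine's place on the ring matters, as 4-bromophenyl or 2-bromophenyl would show, and whether the same change holds in any read-out other than this one.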